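Adding a Hydroxy Group to an Inactive Core

The compounds below may be only part of what the source reports. "The series", "measured", "known", "first", "only" and "open" are said of these compounds alone.

Of the compounds shown here, two have so far been tested in a functional assay on NCI-H446 cells (Homo sapiens) for cytotoxicity, read by luminescence and CellTiter-Glo, with a stated time of 24 h; on this read-out lower numbers stand for stronger inhibition and higher numbers for weaker inhibition. Compound 1, `C=C1C[C@]23C[C@@]1(O)CC[C@H]2c1ccc(O/C=C/C(=O)OC)c(C)c1[C@@H]3C(=O)OC`, gives only a limit of the assay, > 10000 nM. Compound 2, `C=C1C[C@]23C[C@@]1(O)CC[C@H]2[C@@]12C=C[C@H](O)[C@@](C)(C(=O)O1)[C@H]2[C@@H]3C(=O)OC`, likewise gives only a limit, > 10000 nM. So compound 2 stands at the limit rather than at a measured number, and (the limit of > 10000 nM in this assay, at which 2 of the 2 values shown sit); neither compound shows measurable cytotoxicity on these cells.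

The next compound, compound 3, `C=C1[C@@H](O)[C@]23C[C@@]1(O)CC[C@H]2[C@@]12C=C[C@H](O)[C@@](C)(C(=O)O1)[C@H]2[C@@H]3C(=O)OC`, differs from compound 2 in one place: hydroxy in place of hydrogen on a saturated ring carbon. Among the compounds with values here, no pair of measured compounds in this set shares this change, so there is no measured step to guide its size. With nothing pointing either way, the expected step from this change is none beyond the scatter, as a step that the limit leaves unreadable from compound 2 to compound 3 expresses. Compound 3 is therefore expected to remain without measurable activity in this assay, with an estimated value of 20000 nM, between 5000 nM and 80000 nM, and most likely the assay will again report only a limit.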

Compound 3, half-maximal inhibitory concentration: > 10000 nM
Compound 3 ended at the assay's limit; the forecaster's own chance of this, stated with the estimate: 80%; the middle value is on the limit's open side.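

In this assay compound 3 gives > 10000 nM, which is a limit and not a number. Compound 2 also stands at a limit, so no size can be read for the change from compound 2 to compound 3. The compounds shown leave open whether this added hydroxy affects cytotoxicity at all, and what true value any of the three compounds would have: the limit of > 10000 nM in this assay, at which 3 of the 3 values shown sit.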